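Swapping the dichlorophenyl for a small saturated ring

This account rests on a few compounds, and the source may have more. Where it says the series, first, only, none or still open, it means among the compounds named here.

Measured so far:
- compound 1, `COc1ccccc1C(=O)Nc1cccc(NC(=O)c2ccc(Cl)c(Cl)c2)c1`: > 30000 nM
- compound 2, `COc1ccccc1C(=O)Nc1cccc(NC(=O)c2cccc(C#N)c2)c1`: 1800 nM
- compound 3, `COc1ccccc1C(=O)Nc1cccc(NC(=O)C2CCCCC2)c1`: > 30000 nM

In an in vitro functional assay on HEK293-A cells for antagonist activity at metabotropic glutamate receptor 5 (Rattus norvegicus), read by calcium flux (a higher number here means a weaker inhibitor, a lower number a stronger inhibitor), compound 1 gives only a limit, > 30000 nM, and not a number. Compound 3 also sits at a limit, > 30000 nM. Compound 2, with a 3-cyanophenyl on the carbonyl carbon, gives 1800 nM, so the step of an at least 16-fold lower number from compound 1 to compound 2 (1.22 log units; beyond the scatter) is large. The step that the two limits leave unreadable from compound 1 to compound 3 cannot be read, because both values are limits (the limit of > 30000 nM in this assay, at which 2 of the 3 values shown sit). The step of an at least 16-fold higher number from compound 2 to compound 3 (1.22 log units; beyond the scatter) shows that replacing an aromatic ring by a saturated cyclohexyl on that carbonyl carbon costs a great deal of potency.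

Compound 4, `COc1ccccc1C(=O)Nc1cccc(NC(=O)C2CC2)c1`, is not yet measured. It differs from compound 1 in one place: cyclopropyl in place of 3,4-dichlorophenyl on a carbonyl carbon. The cyclopropyl entering here is, like the cyclohexyl of compound 3, a saturated carbon ring, and compound 3 sits at the limit > 30000 nM. Compound 1 itself already sits at a limit, so no readable step in this assay is expected, and the estimated step of a number no higher from compound 1 to compound 4 (the limit leaves the size open) is best read as staying at the limit. Compound 4 is therefore expected to give about 30000 nM, within a range of 10000 nM to 100000 nM.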

Compound 4, half-maximal inhibitory concentration: > 30000 nM
Compound 4 gave a limit, no number; the forecaster's own chance of this, stated with the estimate: 70%; the middle value lies on the limit itself.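

In this assay, the result adds a second saturated ring to the picture, and the step is again large: an at least 16-fold higher number from compound 2 to compound 4 (1.22 log units; beyond the scatter). Going from the cyclohexyl of compound 3 to the much smaller cyclopropyl of compound 4 brings back no readable inhibition, so at this carbonyl carbon neither saturated ring matches the 3-cyanophenyl of compound 2, whatever the ring's size among these two. The steps among compound 1, compound 3 and compound 4 cannot be read, since all three values are limits and not numbers: the limit of > 30000 nM in this assay, at which 3 of the 4 values shown sit.

As far as these compounds go, how a plain phenyl ring or a pyridine ring would fare on this carbonyl carbon stays open, and with it the question of whether the nitrile is what separates compound 2 from compound 1, which also carries an aromatic ring and yet gives only a limit. Also open, from the compounds shown here alone, is whether a saturated ring bearing an amine, or a longer chain such as n-butyl, would give a number here and not a limit.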